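This account rests on a few compounds, and the source may have more. Where it says the series, first, only, none or still open, it means among the compounds named here.

The series rests on a shared core, carried in compound 1 `Nc1cc(N)c2nc(-c3ccccc3)c(Oc3ccc(Cl)c(Cl)c3)nc2c1`, compound 2 `COc1ccc(CNc2nc3cc(N)cc(N)c3nc2-c2ccccc2)cc1OC` and compound 3 `COc1cc(CNc2nc3cc(N)cc(N)c3nc2-c2ccccc2)cc(OC)c1OC`. In a functional assay on NCI/ADR-RES cells (Homo sapiens) for inhibition, read by sulforhodamine B assay, with a stated time of 48 h (on this read-out higher numbers stand for lower toxicity in this test and lower numbers for higher toxicity in this test), compound 1 gives only a limit, < 100000 nM. In this assay compound 2 likewise gives only a limit, < 100000 nM. Compound 3, in this assay, gives 46800 nM. Going by the values given here, the one measured step, a step that the limit leaves unreadable from compound 2 to compound 3, cannot be sized, because the limit of < 100000 nM in this assay, at which 2 of the 3 values shown sit, leaves its starting point open. Compound 2 thus stands on a limit rather than a number, and nothing measured tells how far a change in the methoxy substitution moves the read-out.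

Compound 4 `COc1ccc(CNc2nc3cc(N)cc(N)c3nc2-c2ccccc2)cc1` differs from compound 2 by hydrogen in place of methoxy on an aromatic carbon. Among the compounds with values here, no measured step bears on this change in a readable size: the only neighbouring step is the unreadable one just described. With no readable step to lean on, the expectation is that compound 4 stays within the scatter of compound 2, so the expected step for compound 4 is a step that the limit leaves unreadable from compound 2 to compound 4. Compound 4 is therefore estimated at 60000 nM in this assay, within an expected range from 20000 nM to 150000 nM, with a real chance that only a limit is reported again.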

Compound 4, concentration lethal to 50% of the cells: < 100000 nM
Compound 4: only a limit was reported; the forecaster's own chance of this, stated with the estimate: 50%; the middle value is on the limit's open side.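

Going by these compounds alone, compound 4, like compound 2, gives only a limit in this assay, so no step between compound 2 and compound 4 can be read, and the change from 3,4-dimethoxyphenyl to 4-methoxyphenyl has no measurable size here: the limit of < 100000 nM in this assay, at which 3 of the 4 values shown sit.

The compounds shown leave open how far, if at all, this change moves the read-out.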